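A few compounds are considered here, and "the series" means these few. Any claim that something is new, unique, unknown or untested is made for them only; others in the source may bear on it.

In an assay on HEK293 cells for activation of Kir3.1/Kir3.2 (Homo sapiens), read by thallium flux (a lower number here means that less compound is needed, a higher number that more compound is needed for the effect), compound 1 `CCC(C)n1nc(C)cc1NC(=O)Cn1nnc(-c2ccccc2)n1` gives only a limit, > 5000 nM, and not a number. Compound 2 `Cc1cc(NC(=O)Cn2nnc(-c3cccc(F)c3)n2)n(C2CCCCC2)n1` gives 81 nM in this assay, the only real number shown here. Compound 3 `Cc1cc(NC(=O)Cn2nnc(-c3ccc(C(F)(F)F)cc3)n2)n(C2CCCCC2)n1` differs from compound 2 by 4-(trifluoromethyl)phenyl in place of 3-fluorophenyl on an aromatic carbon. No pair of measured compounds differing in one place is shown, so the size of this step in this assay is uncertain; a modest shift toward needing more compound is expected, though one within the scatter cannot be excluded. Compound 3 is expected to give about 200 nM, between 50 nM and 1500 nM. That expectation means a step of a 2.5-fold higher number from compound 2 to compound 3 (0.39 log units; beyond the scatter) in this assay.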

Compound 3, half-maximal effective concentration: 241 nM
Beside the measured number, compound 3's estimate is 1.2-fold (0.08 log units) below it; low and high end bracket the measured number.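

In this assay the change to 4-(trifluoromethyl)phenyl on this carbon of the five-membered ring gives a 3.0-fold higher number from compound 2 to compound 3 (0.47 log units; beyond the scatter) and so costs only modestly. This is the only single-place step shown, and it shows that this position still gives a real number with the larger group, 10 heavy atoms in place of 7. Compound 3 also stays clear of the assay limit: the limit of > 5000 nM in this assay, at which 1 of the 3 values shown sits.

The group and its place on the phenyl ring change together, so their shares in the step stay unresolved. As far as these compounds go, whether an amine or a carboxylic acid on the phenyl ring would be accepted also stays open.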